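From Hydroxymethyl to Methanesulfonamido: An Untested Step

The compounds below may be only part of what the source reports. "The series", "measured", "known", "first", "only" and "open" are said of these compounds alone.

Compound 1 `Oc1ccc2cc(-c3ccccc3O)ccc2c1` registers in an assay for binding affinity to 17-beta-hydroxysteroid dehydrogenase type 2 (Homo sapiens), with a stated time of 20 min, tested at 1 uM (on this read-out lower numbers stand for less inhibition and higher numbers for more inhibition at the one concentration tested (going by the name of the read-out)), only as a limit of the assay, < 10%; (the limit of < 10% in this assay, at which 1 of the 2 values shown sits). Within the data shown here, compound 2 `OCc1ccc(-c2ccc3c(O)cccc3c2)cc1` gives 31% in this assay, the only actual number among the two values, and no measured step leads to or from it. Compound 3 `CS(=O)(=O)Nc1ccc(-c2ccc3c(O)cccc3c2)cc1` differs from compound 2 by methanesulfonamido in place of hydroxymethyl on an aromatic carbon. Among the measured compounds shown here, with no measured step of this kind to draw on, the expected change from compound 2 to compound 3 is a number 4 percentage points higher from compound 2 to compound 3 (within the scatter), a shift not expected to go far beyond the usual scatter in either direction. Compound 3 is therefore estimated at 35%, most plausibly between 10% and 60%.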

Compound 3, a percentage reported as inhibition, at one concentration (the size of the read-out at that concentration, not a potency): 75%
Compound 3: the middle estimate sits 40 percentage points below what was measured; measured number above the stated range.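

Methanesulfonamido in place of hydroxymethyl on an aromatic carbon, para to a large group, gives a number 44 percentage points higher from compound 2 to compound 3 (beyond the scatter) in this assay. Among these compounds, the earlier compounds offered no measured step, so this is the first sign that the read-out responds to what this position carries. No measurement shown bears on why the step has this size.

As far as these compounds go, it remains open whether an amine or a carboxylic acid at this position would match compound 3, and whether a longer chain in place of the methyl of methanesulfonamido would keep its value.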